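Series notes: aryl swap on the ring nitrogen of compound 1

The compounds below may be only part of what the source reports. "The series", "measured", "known", "first", "only" and "open" are said of these compounds alone.

Compound 1 `Cc1c(C(=O)Nc2ccc(C(F)(F)F)cc2)cnn1-c1ccc(F)c(Cl)c1` gives 1300 nM in a functional assay with Homo sapiens as the target (a lower number here means a stronger inhibitor, a higher number a weaker inhibitor), and stands second highest of the three numbers measured; compound 3 `CCCCC(CC)NC(=O)c1cnn(-c2ccc(F)cc2)c1C` gives 580 nM, and compound 2 `COc1cccc(NC(=O)c2cnn(-c3ccc(F)cc3)c2C)c1` gives 3700 nM. Within the data shown here, the one measured step, a 6.4-fold lower number from compound 2 to compound 3 (0.80 log units; beyond the scatter), changes the group on the amide-type nitrogen, not the group on the aromatic nitrogen, so it does not bear on the change at hand. Compound 4 `COc1ccc(-n2ncc(C(=O)Nc3ccc(C(F)(F)F)cc3)c2C)cc1` differs from compound 1 in 4-methoxyphenyl in place of 3-chloro-4-fluorophenyl on an aromatic nitrogen. Among the measured compounds shown here, no measured pair changes the group on the aromatic nitrogen alone; compound 2 and compound 3 both carry 4-fluorophenyl there, but each also differs from compound 1 at the amide, so their values give no clean reading of this position. With nothing to anchor the step, the expected change from compound 1 to compound 4 is a 1.4-fold higher number from compound 1 to compound 4 (0.14 log units; within the scatter), that is, none beyond the scatter, with a wide range. Compound 4 is estimated at 1800 nM, between 500 nM and 6500 nM.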

Compound 4, half-maximal inhibitory concentration: 340 nM
For compound 4 the middle estimate is 5.3-fold (0.72 log units) above the measured one, outside the stated range (below it).
By their numbers in this assay, from the lowest: compounds 4 and 3 (each within the scatter of the next); then compound 1; then compound 2.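

Among these compounds, this is the first clean reading of the group on the aromatic nitrogen: with the rest of compound 1 held constant, 4-methoxyphenyl in place of 3-chloro-4-fluorophenyl gives a 3.8-fold lower number from compound 1 to compound 4 (0.58 log units; beyond the scatter) in this assay. The position therefore responds to the choice of aryl group, and an aryl group without halogen is accepted there with no loss. Nothing on hand accounts for the gain.

The step changes several things at once, so the compounds shown do not separate the removal of chlorine, the removal of fluorine and the addition of methoxy. Also open, on these data alone, are how a 4-hydroxyphenyl or 4-ethoxyphenyl group would read on that nitrogen, and whether the step carries over to the 1-ethylpentyl amide of compound 3.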